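The source may hold more compounds than are shown below. What is called first, only, known or untested is meant among the compounds shown, and "the series" means these compounds.

Of the compounds shown here, two have been tested in an assay on isolated protein for inhibition of Alpha glucosidase (Homo sapiens), with stated times of 5 min and 15 min, tested at 50 uM; on this read-out higher numbers stand for more inhibition at the one concentration tested (going by the name of the read-out) and lower numbers for less inhibition. Compound 1 `O=C1/C(=C/c2ccccc2)CCC/C1=C\c1cccc(Br)c1` gives 27.2% in this assay, the lower of the two numbers shown. Compound 2 `O=C(C1=C(O)/C(=C/c2ccc(O)cc2)CCC1)c1ccccc1` gives 34.9% in this assay, a gap to compound 1 that stays within the usual scatter, so the two cannot be told apart with confidence. Compound 3 `O=C1/C(=C/c2ccccc2)CCC/C1=C\c1ccc(O)cc1` has not been measured yet. It differs from compound 1 in one place: 4-hydroxyphenyl in place of 3-bromophenyl on a double-bonded chain carbon bound to a double-bonded ring carbon. Among the compounds with values here, no pair of measured compounds isolates this exchange, so its effect cannot be read from the data directly. Compound 2 also carries a 4-hydroxyphenyl, and its value does not stand apart from that of compound 1. The step of a number 3.8 percentage points higher from compound 1 to compound 3 (within the scatter) is therefore expected to be small, within the scatter, leaning if anything slightly upward. Compound 3 is estimated at 31%, most likely between 18% and 45%.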

Compound 3, a percentage reported as inhibition, at one concentration (the size of the read-out at that concentration, not a potency): 53%
Estimate against measurement, compound 3: 22 percentage points below; the whole stated range lies below it.
By their numbers in this assay, from the lowest: compounds 1 and 2 (each within the scatter of the next); then compound 3.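

This place on the shared core is not indifferent to the group it carries: in this assay, putting 4-hydroxyphenyl in place of 3-bromophenyl gives a number 25.8 percentage points higher from compound 1 to compound 3 (beyond the scatter) and so clearly changes the read-out. Within the data shown here, the earlier values could not show this, as no measured pair isolated the exchange at a double-bonded chain carbon bound to a double-bonded ring carbon. Nothing measured here explains why the number rises.

The exchange removes the bromine and adds the hydroxyl while also changing the numbered place of the substituent, so the compounds shown cannot separate the role of the atom from that of its location. On these data alone, neither 3-hydroxyphenyl nor 4-bromophenyl is among them, and neither is a related group such as 4-methoxyphenyl or 4-aminophenyl, so how specific the step is to 4-hydroxyphenyl remains open.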